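Methyl to fluoro at the weak end of the series

The source may hold more compounds than are shown below. What is called first, only, known or untested is meant among the compounds shown, and "the series" means these compounds.

Compound 1 `CCCCOc1ccc(C(=O)NNC(=O)c2ccccc2NS(=O)(=O)c2cnc(O)nc2O)cc1`: 4960 nM
Compound 2 `Cc1ccc(C(=O)NNC(=O)c2ccccc2NS(=O)(=O)c2cnc(O)nc2O)cc1`: > 20000 nM

In a functional assay on A549 cells (Homo sapiens) for antiproliferative activity, read by MTT assay, with a stated time of 24 h (on this read-out higher numbers stand for weaker inhibition and lower numbers for stronger inhibition), compound 1 gives 4960 nM. Compound 2 reads > 20000 nM, which is a limit of the assay and not a number; this is the limit of > 20000 nM in this assay, at which 1 of the 2 values shown sits. Compound 3 `O=C(NNC(=O)c1ccccc1NS(=O)(=O)c1cnc(O)nc1O)c1ccc(F)cc1` carries fluoro in place of methyl on the same aromatic carbon: fluoro in place of methyl on an aromatic carbon. Within the data shown here, the only measured step bearing on it is an at least 4.0-fold higher number from compound 1 to compound 2 (0.60 log units; beyond the scatter), with methyl replacing butoxy at that position. That step involves no fluoro, so no step beyond the scatter is expected, and no direction is favoured. The estimated change is a step that the limit leaves unreadable from compound 2 to compound 3. Compound 3 is expected near 25000 nM, with an estimated range from 9000 nM to 50000 nM, quite possibly reported only as a limit.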

Compound 3, half-maximal inhibitory concentration: > 20000 nM
Compound 3: no number, only a limit; the forecaster's own chance of this, stated with the estimate: 65%; the middle value lies beyond the limit too.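

Fluoro in place of butoxy gives an at least 4.0-fold higher number from compound 1 to compound 3 (0.60 log units; beyond the scatter), so in this assay fluoro, like methyl before it, reads weaker than butoxy at this position. The values of compound 2 and compound 3 are both limits, so the step between them cannot be read and methyl and fluoro cannot be ranked: the limit of > 20000 nM in this assay, at which 2 of the 3 values shown sit.

From the compounds shown here alone, whether any activity remains with methyl or fluoro stays open. So does whether a longer chain such as hexyloxy, or an amine at this position, would read differently from the butoxy of compound 1.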